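A few compounds are considered here, and "the series" means these few. Any claim that something is new, unique, unknown or untested is made for them only; others in the source may bear on it.

Measured so far:
- compound 1, `O=C(O)CCCSCCN1C(=O)OC[C@@H]1/C=C/[C@@H](O)Cc1ccccc1`: in an assay on CHO cells for displacement of a labelled ligand from prostaglandin E2 receptor EP3 subtype (Mus musculus), read by scintillation counting, with a stated time of 60 min (on this read-out lower numbers stand for stronger inhibition and higher numbers for weaker inhibition), compound 1 gives 6400 nM
- compound 2, `Cc1cccc(C[C@H](O)/C=C/[C@H]2CCC(=S)N2CCSCCCC(=O)O)c1`: in this assay compound 2 gives 980 nM

Of the two measured compounds, compound 1 has the higher number, and the gap to compound 2 lies beyond the usual scatter of repeat measurements, so compound 1 is the weaker binder of the pair. Compound 2 differs from compound 1 in more than one place at once, so the two values show only that the combination of its changes lowers the number; they do not tell which change does what.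

Compound 3, `COCc1cccc(C[C@H](O)/C=C/[C@H]2COC(=O)N2CCSCCCC(=O)O)c1`, keeps the whole framework of compound 1 and changes a single spot: methoxymethyl in place of hydrogen on an aromatic carbon. Among the compounds with values here, no measured pair in this set isolates that change, so the expected step rests on the neighbouring data alone, namely that a substituted aromatic ring in compound 2 goes with a lower number than the bare ring of compound 1. In this assay the expected change is a 2.1-fold lower number from compound 1 to compound 3 (0.33 log units; beyond the scatter). For compound 3 the estimated value is 3000 nM, with a range from 1000 nM to 9000 nM.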

Compound 3, inhibition constant: > 10000 nM
Compound 3 was reported as a limit; the forecaster's own chance of this, stated with the estimate: 5%; at least 3.3-fold (0.52 log units) between middle value and limit.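

In this assay compound 3 is reported only as a limit, not as a number: the limit of > 10000 nM in this assay, at which 1 of the 3 values shown sits. Within the data shown here, compounds 1 and 3 form the only pair here that isolates a change on the aromatic ring, and putting methoxymethyl in place of hydrogen on this aromatic carbon gives an at least 1.5-fold higher number from compound 1 to compound 3 (0.19 log units; that floor lies within the scatter). Since the floor of that step lies within the scatter, a real loss of binding cannot be claimed, but the pair gives no sign that this group lowers the number on the framework of compound 1, so the lower number of compound 2 cannot be credited to ring substitution in general.

The limit leaves open how much weaker than the reported bound compound 3 might truly be, and whether methoxymethyl at this place would act the same way on the core of compound 2. On these data alone, it also remains open whether a different group on this aromatic carbon, such as a fluorine atom, an amine or a longer ether chain, would shift the number in either direction.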